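Trifluoromethyl for Chloro on the Aryl Urea Terminus

The source may hold more compounds than are shown below. What is called first, only, known or untested is meant among the compounds shown, and "the series" means these compounds.

The shared core of compound 1, `O=C(Nc1cccc(-n2cc(-c3ccncc3)c(-c3ccc(Cl)c(O)c3)n2)c1)Nc1ccc(Cl)c(Cl)c1`, carries a urea whose outer ring is a 3,4-dichlorophenyl group. In a functional assay on KM12 cells (Homo sapiens) for inhibition, read by sulforhodamine B assay, with a stated time of 48 h (a lower number here means a stronger inhibitor of growth, a higher number a weaker inhibitor of growth), compound 1 gives 4470 nM, the highest of the two numbers recorded. Its nearest neighbour is compound 2, `O=C(Nc1cccc(-n2cc(-c3ccncc3)c(-c3ccc(Cl)c(O)c3)n2)c1)Nc1cc(C(F)(F)F)cc(C(F)(F)F)c1`, which in this assay gives 1430 nM; the gap between them lies beyond the scatter. Compound 3, `O=C(Nc1cccc(-n2cc(-c3ccncc3)c(-c3ccc(Cl)c(O)c3)n2)c1)Nc1ccc(Cl)c(C(F)(F)F)c1`, has not yet been measured. It differs from compound 1 by trifluoromethyl in place of chloro on an aromatic carbon, so that the (3,4-dichlorophenyl)amino becomes a (4-chloro-3-(trifluoromethyl)phenyl)amino. Because compound 2 gives 1430 nM with two trifluoromethyl groups on the same ring, a modest step toward a lower number is expected in this assay, of about a 1.8-fold lower number from compound 1 to compound 3 (0.25 log units; within the scatter). Compound 3 is therefore estimated at 2500 nM, within 1000 nM to 6000 nM.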

Compound 3, concentration for total growth inhibition: 3510 nM
Compound 3: the middle estimate sits 1.4-fold (0.15 log units) below what was measured, within the range that was stated.
By their numbers in this assay, from the lowest: compound 2; then compounds 3 and 1 (each within the scatter of the next).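

In this assay, for the compounds shown here, trifluoromethyl in place of chloro on this aromatic carbon, ortho to a chloro group, is the first change in a single place that can be read, and it amounts to a 1.3-fold lower number from compound 1 to compound 3 (0.11 log units; within the scatter). Four heavy atoms can thus enter where one leaves on this outer ring of the urea while the number stays within the scatter. Nothing available here explains this result or ties it to a property of either group.

The compounds shown leave open whether an amine, a methoxy group or a nitrile on this carbon would give a step beyond the scatter. Compound 2 differs from compound 1 in more than one place, and the share of each of its trifluoromethyl groups in its value cannot be read from these compounds.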